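The source may report more compounds than this note shows. Statements on the series, on what has been measured and on what is new or still open speak of the compounds shown alone.

The measured compounds are:

compound 1, `O=C(CSc1nc2ccc(NC(=O)CCl)cc2s1)NCc1ccccc1`, which in a functional assay on MCF7 cells (Homo sapiens) for cytotoxicity, read by MTT assay, with a stated time of 48 h (on this read-out lower numbers stand for stronger inhibition and higher numbers for weaker inhibition), gives 4200 nM;
compound 2, `COc1ccccc1C(=O)Nc1ccc2nc(SCC(=O)NCc3ccccc3)sc2c1`, which in this assay gives 17200 nM;
compound 3, `O=C(CSc1nc2ccc(NC(=O)CCl)cc2s1)NCc1ccc(Cl)cc1`, which in this assay gives 4900 nM.

The change from compound 1 to compound 2 is 2-methoxyphenyl in place of chloromethyl on a carbonyl carbon. That single change brought a 4.1-fold higher number from compound 1 to compound 2 (0.61 log units; beyond the scatter), a modest step that lies beyond the scatter.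

Compound 4, `COc1ccccc1C(=O)Nc1ccc2nc(SCC(=O)NCc3ccc(Cl)cc3)sc2c1`, has not yet been measured in this assay. It stands to compound 3 exactly as compound 2 stands to compound 1: the change is 2-methoxyphenyl in place of chloromethyl on a carbonyl carbon, and it occurs twice among the four compounds. The two cores on which it is made differ by chloro in place of hydrogen on an aromatic carbon; the step for that difference, a 1.2-fold higher number from compound 1 to compound 3 (0.07 log units; within the scatter), is within the scatter, so compound 1 and compound 3 are treated here as giving the same number. The place line of the change on compound 3 reads word for word as it does on compound 1, so this is the same change, not merely the same kind.

On that footing the step from compound 3 to compound 4 is expected to be a 4.1-fold higher number from compound 3 to compound 4 (0.61 log units; beyond the scatter), resting on the measured step of a 4.1-fold higher number from compound 1 to compound 2 (0.61 log units; beyond the scatter) because the two cores themselves differ only by a 1.2-fold higher number from compound 1 to compound 3 (0.07 log units; within the scatter). Compound 4 is therefore estimated at 20000 nM in this assay, with the expected range running from 9000 nM to 45000 nM.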

Compound 4, half-maximal inhibitory concentration: 1100 nM
The estimate for compound 4 lay 18-fold (1.26 log units) above the measured number; the measured number lies below the stated range.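

In this assay, the replacement of chloromethyl by 2-methoxyphenyl on a carbonyl carbon did not carry from one core to the other, for on the chloro-bearing core it gave a 4.5-fold lower number from compound 3 to compound 4 (0.65 log units; beyond the scatter), opposite in direction to the earlier step: the same change on two cores in this assay, a 4.1-fold higher number (0.61 log units; beyond the scatter) from compound 1 to compound 2 and a 4.5-fold lower number (0.65 log units; beyond the scatter) from compound 3 to compound 4, 18-fold (1.26 log units) apart, beyond the scatter of two such steps Read along the other edge of the same four compounds, chloro in place of hydrogen on an aromatic carbon gave a 16-fold lower number from compound 2 to compound 4 (1.19 log units; beyond the scatter) where the 2-methoxyphenyl group is present, although it made no difference beyond the scatter where chloromethyl is present: the same change on two cores in this assay, a 1.2-fold higher number (0.07 log units; within the scatter) from compound 1 to compound 3 and a 16-fold lower number (1.19 log units; beyond the scatter) from compound 2 to compound 4, 18-fold (1.26 log units) apart, beyond the scatter of two such steps In these four compounds, then, neither change has a step of its own that can be carried over, since the outcome of each depends on which form of the other is present, but this single set of four does not show why the two are coupled, nor how far such coupling reaches elsewhere in the series.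

As far as these compounds go, it remains open whether a plain phenyl or a 4-methoxyphenyl in place of the 2-methoxyphenyl would show the same reversal, and whether bromo or methoxy in place of the chloro would do so. From the compounds shown here alone, it is equally open whether the low number of compound 4 is matched by any other amide on this core.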